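The compounds below may be only part of what the source reports. "The series", "measured", "known", "first", "only" and "open" are said of these compounds alone.

Measured so far:
Compound 1 `O=C(O)c1cc(-n2c(-c3ccc(Br)cc3)cc3c2CCCC3)ccc1O`: 40%
Compound 2 `O=C(O)c1cc(-n2c(-c3ccc(Cl)cc3)cc3c2CCCC3)ccc1O`: 40%

In a functional assay on the whole organism (strain Wistar) for inhibition, with Rattus norvegicus as the target, read by paw edema, with stated times of 30 min and 3 h, at a dose of 200 mg/kg by the oral route (on this read-out higher numbers stand for more inhibition at the one dose given (going by the name of the read-out) and lower numbers for less inhibition), compound 2 gives 40% and stands level with compound 1, whose value is 40%. Compound 3 `O=C(O)c1cc(-n2c(-c3cccs3)cc3c2CCCC3)ccc1O` is the next compound; it differs from compound 2 by thiophen-2-yl in place of 4-chlorophenyl on an aromatic carbon. Within the data shown here, the only measured step, no change at the digits printed from compound 1 to compound 2 (within the scatter), concerned chloro in place of bromo on an aromatic carbon and produced no change beyond the scatter. That step speaks only indirectly to a change of the whole ring, so it is taken as a weak guide: no step beyond the scatter is expected in this assay, with wide uncertainty. Compound 3 is therefore expected to give 40%, with a range from 22% to 58%, meaning an expected step of no change at the digits printed from compound 2 to compound 3 (within the scatter).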

Compound 3, a percentage reported as inhibition, in the whole organism at one dose (the size of the read-out at that dose, not a potency): 30%
For compound 3 the middle estimate is 10 percentage points above the measured one, and the stated range covers the measured number.
By their numbers in this assay, from the lowest: compounds 3, 1 and 2 (each within the scatter of the next).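

In this assay, putting thiophen-2-yl in place of 4-chlorophenyl gives a number 10 percentage points lower from compound 2 to compound 3 (within the scatter), and putting it in place of 4-bromophenyl gives a number 10 percentage points lower from compound 1 to compound 3 (within the scatter). The earlier step changed only the halogen, whereas these steps show that the whole six-membered aromatic ring on this carbon, next to the ring nitrogen, can give way to a five-membered aromatic ring with 1 hetero atom without a step beyond the scatter at this single dose. No accompanying measurement helps to explain this result.

Every group shown at this position is an aromatic ring. From the compounds shown here alone, how an amine or a butyl chain would read there remains open.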